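Swapping the Naphthylmethyl Arm for a Plain Phenyl

The source may hold more compounds than are shown below. What is called first, only, known or untested is meant among the compounds shown, and "the series" means these compounds.

Measured compounds:
compound 1 `CCCCn1cc(C(=O)Nc2ccc(C)c(S(=O)(=O)N3CCOCC3)c2)c(-c2ccc(C)cc2)n1`, giving 11500 nM
compound 2 `Cc1ccc(-c2nn(Cc3ccc4ccccc4c3)cc2C(=O)Nc2ccc(C)c(S(=O)(=O)N3CCOCC3)c2)cc1`, giving 844 nM

In an assay on HEK-293T cells for inhibition of Bile acid receptor (Homo sapiens), read by a beta-lactamase reporter, with a stated time of 16 h (on this read-out lower numbers stand for stronger inhibition and higher numbers for weaker inhibition), compound 2 holds the lowest of the two numbers, with compound 1 standing well above it. Among the measured compounds shown here, the single measured step, a 14-fold lower number from compound 1 to compound 2 (1.13 log units; beyond the scatter), shows that the group on the aromatic nitrogen changes the number greatly. Compound 3 `Cc1ccc(-c2nn(-c3ccccc3)cc2C(=O)Nc2ccc(C)c(S(=O)(=O)N3CCOCC3)c2)cc1` carries phenyl in place of (naphthalen-2-yl)methyl on an aromatic nitrogen, so one six-membered aromatic ring now replaces two, without the connecting chain carbon. For the measured compounds named here, no measured step covers this exact change, and a moderate rise in the number is expected: a 3.6-fold higher number from compound 2 to compound 3 (0.55 log units; beyond the scatter). Compound 3 is therefore estimated at 3000 nM, within a range of 800 nM to 12000 nM.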

Compound 3, half-maximal inhibitory concentration: 2620 nM
Compound 3: middle estimate off by 1.1-fold (0.06 log units), on the high side; low and high end bracket the measured number.
By their numbers in this assay, from the lowest: compound 2; then compound 3; then compound 1.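

On the aromatic nitrogen, a phenyl group directly attached gives a clearly better result than butyl, with a 4.4-fold lower number from compound 1 to compound 3 (0.64 log units; beyond the scatter), yet it does not match the larger arm, with a 3.1-fold higher number from compound 2 to compound 3 (0.49 log units; beyond the scatter). So an aromatic ring at this position goes with a lower number in both steps, and the two-ring arm with the connecting carbon gives the lowest of the three. Nothing measured here explains these differences.

From the compounds shown here alone, this change removes a ring and the connecting carbon together, so their separate contributions remain open. Among the compounds shown here, a benzyl group, which keeps the carbon but has only one ring, would help to separate them.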